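A few compounds are considered here, and "the series" means these few. Any claim that something is new, unique, unknown or untested is made for them only; others in the source may bear on it.

Compound 1 `CC(C)CCn1c(=O)c2nc[nH]c2n(CC(C)C)c1=O` is, in an assay on HEK293 cells for binding affinity to adenosine receptor A2b (Homo sapiens), read by radioligand binding (on this read-out lower numbers stand for stronger inhibition and higher numbers for weaker inhibition), the lower of the two numbers available, giving 6240 nM. The other measured compound, compound 2 `CC(=O)Cn1c(=O)c2c(ncn2C)n(C)c1=O`, gives 20800 nM in this assay, a higher number that lies beyond the usual scatter. Compound 3 `CC(C)CCn1c(=O)c2nc(-c3ccccc3)[nH]c2n(CC(C)C)c1=O` is compound 1 with one change: phenyl in place of hydrogen on an aromatic carbon, placed on the aromatic carbon of the five-membered ring, between two ring nitrogen atoms. Among the measured compounds shown here, no measured pair shows this change, so the size of its step in this assay is open. For compound 3 a clearly lower number is expected, estimated at 300 nM with a range from 50 nM to 2000 nM, corresponding to an expected step of a 21-fold lower number from compound 1 to compound 3 (1.32 log units; beyond the scatter).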

Compound 3, inhibition constant: 9890 nM
Estimate against measurement, compound 3: 33-fold (1.52 log units) below, and the stated range ends below it.
By their numbers in this assay, from the lowest: compounds 1 and 3 (each within the scatter of the next); then compound 2.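

In this assay the step of a 1.6-fold higher number from compound 1 to compound 3 (0.20 log units; within the scatter) comes with phenyl in place of hydrogen on the aromatic carbon between two ring nitrogen atoms. Among the compounds shown here, this shows that adding a six-membered aromatic ring at this position leaves the number within the usual scatter, which the earlier compounds could not show. Nothing available here accounts for this result.

Still open, on these data alone, is whether a smaller group on this carbon, such as methyl, or an amine would give a different number. So is whether a phenyl carrying a carboxylic acid would.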